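The source may hold more compounds than are shown below. What is called first, only, known or untested is meant among the compounds shown, and "the series" means these compounds.

Measured so far:
compound 1, `COc1cccc(CNC(=O)c2cccc(C(C)Oc3ccnc(Nc4cnn(C)c4)c3)c2)c1`, > 100000 nM in a functional assay on NCI-H3122 cells (Homo sapiens) for antiproliferative activity, read by MTT assay, with a stated time of 48 h; on this read-out higher numbers stand for weaker inhibition and lower numbers for stronger inhibition; this value is a limit of the assay, not a number (the limit of > 100000 nM in this assay, at which 1 of the 3 values shown sits).
compound 2, `CC(Oc1ccnc(Nc2cnn(C)c2)c1)c1cccc(C(=O)NCc2cc(F)cc(F)c2)c1`, in this assay 7600 nM.
compound 3, `Cc1ccc(CNC(=O)c2cccc(C(C)Oc3ccnc(Nc4cnn(C)c4)c3)c2)cc1`, in this assay 7700 nM.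

Compound 3 gives the higher of the two numbers shown, but its nearest neighbour compound 2 sits within the scatter: a 1.0-fold higher number from compound 2 to compound 3 (0.01 log units; within the scatter). The large steps of an at least 13-fold lower number from compound 1 to compound 2 (1.11 log units; beyond the scatter) and an at least 12-fold lower number from compound 1 to compound 3 (1.11 log units; beyond the scatter) both concern the aryl on the saturated chain carbon bound to the amide-type nitrogen.

Compound 4, `Cc1ccc(CNC(=O)c2cccc(C(C)Oc3ccnc(Nc4nc5ccccc5[nH]4)c3)c2)cc1`, differs from compound 3 elsewhere: 1H-benzimidazol-2-yl in place of 1-methyl-1H-pyrazol-4-yl on a nitrogen on an aromatic ring. Among the compounds with values here, no measured step touches this part of the shared core, so the data give no direction for the change. For compound 4 a number near that of compound 3 is expected, a 1.3-fold lower number from compound 3 to compound 4 (0.11 log units; within the scatter), with a wide range. The estimate for compound 4 is 6000 nM, between 1500 nM and 30000 nM.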

Compound 4, half-maximal inhibitory concentration: 9400 nM
The estimate for compound 4 lay 1.6-fold (0.19 log units) below the measured number; the measured number falls inside the stated range.
By their numbers in this assay, from the lowest: compounds 2, 3 and 4 (each within the scatter of the next). At a limit, above all of these: compound 1.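

In this assay, within the data shown here, the one step at the nitrogen on an aromatic ring reads a 1.2-fold higher number from compound 3 to compound 4 (0.09 log units; within the scatter). With 4-methylphenyl on the saturated chain carbon, 1-methyl-1H-pyrazol-4-yl and the larger 1H-benzimidazol-2-yl, which adds a six-membered aromatic ring of carbon only and a hydrogen-bond donor, are therefore interchangeable at this position on this read-out. Nothing given here bears on the reason for this result.

Open, as far as these compounds go, is whether this holds with 3,5-difluorophenyl or 3-methoxyphenyl on that chain carbon. Also open, from the compounds shown here alone, is how an amine or a carboxylic acid carried on the group at this nitrogen would read.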